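This account rests on a few compounds, and the source may have more. Where it says the series, first, only, none or still open, it means among the compounds named here.

Three compounds share one core and differ only in the group attached to the sulfonyl sulfur. Compound 1 `CC(C)c1cccc(C(C)C)c1NC(=O)NS(=O)(=O)N1CCCC1` carries a pyrrolidin-1-yl group there and, in an assay on liver for inhibition of sterol O-acyltransferase 1 (Rattus norvegicus), using microsomes (on this read-out lower numbers stand for stronger inhibition and higher numbers for weaker inhibition), compound 1 gives 15000 nM. Compound 2 `C=CCN(CC)S(=O)(=O)NC(=O)Nc1c(C(C)C)cccc1C(C)C` carries an allyl(ethyl)amino group instead, and in this assay compound 2 gives 2100 nM, which is a 7.1-fold lower number from compound 1 to compound 2 (0.85 log units; beyond the scatter). Compound 3 `CCCCCCNS(=O)(=O)NC(=O)Nc1c(C(C)C)cccc1C(C)C` carries a hexylamino group, and in this assay compound 3 gives 8100 nM. That places compound 3 second highest of the three numbers: the move to it is a 1.9-fold lower number from compound 1 to compound 3 (0.27 log units; within the scatter), while a 3.9-fold higher number from compound 2 to compound 3 (0.59 log units; beyond the scatter).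

Compound 4 `CC(C)c1cccc(C(C)C)c1NC(=O)NS(=O)(=O)N1CCCCC1` is the next step from compound 3. The change is piperidin-1-yl in place of hexylamino on a sulfonyl sulfur. It swaps an open chain for a ring, as the step from compound 3 back toward compound 1 would; that earlier comparison, a 1.9-fold lower number from compound 1 to compound 3 (0.27 log units; within the scatter), stayed within the scatter, so a ring of one more member is expected to land near compound 1 and compound 3 rather than near compound 2. The step from compound 3 to compound 4 in this assay is therefore expected to be small, a 1.5-fold higher number from compound 3 to compound 4 (0.17 log units; within the scatter), most likely a slightly higher number. The estimate for compound 4 in this assay is 12000 nM, expected to fall between 4000 nM and 36000 nM.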

Compound 4, half-maximal inhibitory concentration: 17000 nM
Compound 4: middle estimate off by 1.4-fold (0.15 log units), on the low side; measured number inside the range.
By their numbers in this assay, from the lowest: compound 2; then compounds 3, 1 and 4 (each within the scatter of the next, the first and the last beyond it).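

Adding one ring member makes no readable difference in this assay: the pyrrolidin-1-yl and piperidin-1-yl groups lie within the scatter of each other (a 1.1-fold higher number from compound 1 to compound 4 (0.05 log units; within the scatter)), so the two rings shown cannot be separated. The open chain and the ring can now be told apart, though only modestly, since replacing hexylamino with piperidin-1-yl gives a step just beyond the scatter (a 2.1-fold higher number from compound 3 to compound 4 (0.32 log units; beyond the scatter)), whereas the comparison of hexylamino with the smaller ring stayed within it. The widest gap so far separates the piperidin-1-yl compound from the compound with two open chains on the nitrogen (an 8.1-fold higher number from compound 2 to compound 4 (0.91 log units; beyond the scatter)); neither group has a hydrogen-bond donor, so losing the donor of hexylamino does not by itself go with a low number, and nothing available here explains any of these differences.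

Going by these compounds, it remains open whether the lower number of compound 2 depends on its allyl group or simply on having two short chains on the nitrogen, which a diethylamino group would test. Also unsettled is how a ring with a second hetero atom, such as morpholin-4-yl, or a seven-membered azepan-1-yl ring would compare.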